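The source may hold more compounds than are shown below. What is called first, only, known or untested is meant among the compounds shown, and "the series" means these compounds.

Of the compounds shown here, three sharing one core have been measured in a functional assay on Gurav cells (Homo sapiens) for cytotoxicity, read by sulforhodamine B assay, with a stated time of 48 h; a higher number here means a weaker inhibitor of growth, a lower number a stronger inhibitor of growth. Compound 1 `Cc1c(NC(=O)COc2ccc(/C=C3\SC(=O)NC3=O)cc2)c(=O)n(-c2ccccc2)n1C` gives a value that is only a limit of the assay, < 100000 nM. Compound 2 `O=C(COc1ccc(/C=C2\SC(=O)NC2=O)cc1)Nc1nc2ccccc2s1` likewise gives only a limit, < 100000 nM. Compound 3 `O=C(COc1ccc(/C=C2\SC(=O)NC2=O)cc1)Nc1ncc([N+](=O)[O-])s1` also gives only a limit, < 100000 nM. For the measured compounds named here, the one single-point step among them, a step that the two limits leave unreadable from compound 2 to compound 3, therefore cannot be read in size or direction, and the evidence reduces to the limit of < 100000 nM in this assay, at which 3 of the 3 values shown sit.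

Compound 4 `O=C(COc1ccc(/C=C2\SC(=O)NC2=O)cc1)Nc1ccccn1` differs from compound 3 in one place: pyridin-2-yl in place of 5-nitro-1,3-thiazol-2-yl on an amide-type nitrogen. Going by the values given here, no measured step speaks directly to this exchange, and the only step that touches the same position is unreadable. Among the compounds with values here, with every value so far sitting at a limit, the expectation for compound 4 in this assay is a step that the limit leaves unreadable from compound 3 to compound 4 from compound 3, which is no step that can be told from the scatter. Compound 4 is estimated to give 50000 nM, within a range of 5000 nM to 100000 nM, most likely again reported as a limit.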

Compound 4, concentration for total growth inhibition: < 100000 nM
Compound 4 was reported as a limit; the forecaster's own chance of this, stated with the estimate: 80%; the middle value lies beyond the limit too.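

Compound 4 gives only a limit in this assay, so the steps to it from compound 2 and compound 3 cannot be read, and the evidence stays the same: the limit of < 100000 nM in this assay, at which 4 of the 4 values shown sit.

The compounds shown leave open whether the group on the amide-type nitrogen changes growth inhibition at all, and by how much.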